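The source may hold more compounds than are shown below. What is called first, only, known or untested is meant among the compounds shown, and "the series" means these compounds.

Measured so far in a functional assay on the whole organism (strain albino) for inhibition, with Rattus norvegicus as the target, read by paw edema, with stated times of 30 min and 2 h, at a dose of 0.28 mmol/kg by the oral route; a higher number here means more inhibition at the dose given (going by the name of the read-out), a lower number less inhibition:
compound 1 `C=CCn1c(SCC(=O)Nc2ccc(C(C)=O)cc2)nnc1-c1ccccc1` gives 52%
compound 2 `CCn1c(SCC(=O)Nc2ccc(C(C)=O)cc2)nnc1-c1ccc(OC)cc1` gives 54%
compound 3 `C=CCn1c(SCC(=O)Nc2ccc(/C(C)=N/O)cc2)nnc1-c1ccc(OC)cc1` gives 59%

Compound 3 shows the highest of the three numbers, yet its gaps to compound 2 and to compound 1 both fall within the usual scatter, so no ordering among the three can be claimed. The step to compound 4 `C=CCn1c(SCC(=O)Nc2ccc(C(C)=O)cc2)nnc1-c1ccc(OC)cc1` changes one group on an aromatic carbon: a group of 3 heavy atoms (2 carbon, 1 oxygen; no ring) in place of a group of 4 heavy atoms (2 carbon, 1 nitrogen, 1 oxygen; no ring), on an aromatic carbon. The acetyl that enters is the same group carried by compound 1 and compound 2, whose numbers sit close to that of compound 3. For the measured compounds named here, no measured pair shows this exact exchange; the expectation rests on those three numbers alone. The step of a number 4 percentage points lower from compound 3 to compound 4 (within the scatter) is expected to be small, in no particular direction, and to stay within the scatter. Compound 4 is therefore expected to give 55%, with a range from 45% to 65%.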

Compound 4, a percentage reported as inhibition, in the whole organism at one dose (the size of the read-out at that dose, not a potency): 51%
For compound 4 the middle estimate is 4 percentage points above the measured one; measured number inside the range.
By their numbers in this assay, from the lowest: compounds 4, 1, 2 and 3 (each within the scatter of the next).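

In this assay, acetyl in place of the group of 4 heavy atoms on the aromatic carbon, para to a large group, gives (a number 8 percentage points lower from compound 3 to compound 4 (within the scatter)), so the two groups cannot be told apart at this position. The same holds for vinyl in place of methyl on the saturated chain carbon bound to an aromatic nitrogen (a number 3 percentage points lower from compound 2 to compound 4 (within the scatter)) and for methoxy in place of hydrogen on an aromatic carbon (a number 1 percentage points lower from compound 1 to compound 4 (within the scatter)). No supporting measurement bears on these numbers.

On these data alone, whether a carboxylic acid or an amine at the para position, or a longer chain on the aromatic nitrogen, would give a step beyond the scatter remains open.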